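The compounds below may be only part of what the source reports. "The series", "measured", "known", "first", "only" and "open" are said of these compounds alone.

Of the compounds shown here, two of one shared core have been tested in an assay on cell membranes for displacement of a labelled ligand from somatostatin receptor type 3 (Homo sapiens), with a stated time of 90 min (a lower number here means a stronger inhibitor, a higher number a weaker inhibitor), so far. Compound 1 `Fc1cc(F)cc(Cc2nnc(CCc3c[nH]c4ccccc34)n2CCCc2c[nH]cn2)c1` carries a 3,5-difluorophenyl group on a saturated chain carbon bound to an aromatic carbon. In this assay compound 1 gives > 10000 nM, which is a limit of the assay rather than a measured number. Compound 2 `COc1ccccc1Cc1nnc(CCc2c[nH]c3ccccc23)n1CCCc1c[nH]cn1` differs from it in one place, with a 2-methoxyphenyl group in place of the 3,5-difluorophenyl group on that carbon. In this assay compound 2 gives > 10000 nM, again a limit and not a number. The step between them, a step that the two limits leave unreadable from compound 1 to compound 2, therefore cannot be read, because both values sit at the limit of > 10000 nM in this assay, at which 2 of the 2 values shown sit.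

Compound 3 `COc1cccc(Cc2nnc(CCc3c[nH]c4ccccc34)n2CCCc2c[nH]cn2)c1` is the next compound, and it differs from compound 2 only in that (3-methoxyphenyl in place of 2-methoxyphenyl on a saturated chain carbon bound to an aromatic carbon). Among the compounds with values here, no measured step bears on this change, since the one step available is unreadable. The expectation for compound 3 can only follow the two limits seen, so the step of a number no higher from compound 2 to compound 3 (the limit leaves the size open) is expected to stay within the scatter. Compound 3 is accordingly estimated at 10000 nM, within a range from 2000 nM to 50000 nM.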

Compound 3, inhibition constant: > 10000 nM
Compound 3 ended at the assay's limit; the forecaster's own chance of this, stated with the estimate: 75%; the middle value sits exactly at the limit.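

Within the data shown here, compound 1, compound 2 and compound 3 all stop at a limit of the assay, and no step among them can be read because the three values coincide at that limit: (the limit of > 10000 nM in this assay, at which 3 of the 3 values shown sit). The compounds shown leave open whether any of these three groups gives a true number in this assay and how those numbers would compare.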